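Loss of the benzyl group on the aniline nitrogen of compound 3

A few compounds are considered here, and "the series" means these few. Any claim that something is new, unique, unknown or untested is made for them only; others in the source may bear on it.

Compounds measured in a functional assay on CCRF-CEM cells (Homo sapiens) for cytotoxicity, in the absence of a further agent; a higher number here means a weaker inhibitor, a lower number a stronger inhibitor:
compound 1 `Nc1nc(N)c(CCCNc2cc(F)c(F)cc2[N+](=O)[O-])c(O)n1` gives > 100000 nM, a limit of the assay.
compound 2 `Nc1nc(N)c(CCCN(Cc2ccc(NC(CCC(=O)O)C(=O)O)cc2)c2cc(F)c([N+](=O)[O-])cc2[N+](=O)[O-])c(O)n1` gives 44000 nM.
compound 3 `COC(=O)c1ccc(CN(CCCc2c(N)nc(N)nc2O)c2cc(F)c([N+](=O)[O-])cc2[N+](=O)[O-])cc1` gives 3900 nM.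

Compound 3 holds the lowest of the two numbers; its nearest neighbour is compound 2, reached through an 11-fold lower number from compound 2 to compound 3 (1.05 log units; beyond the scatter). The value of compound 1 is a limit only (the limit of > 100000 nM in this assay, at which 1 of the 3 values shown sits).

Compound 4 `Nc1nc(N)c(CCCNc2cc(F)c([N+](=O)[O-])cc2[N+](=O)[O-])c(O)n1` differs from compound 3 in one place: hydrogen in place of 4-(methoxycarbonyl)benzyl on a nitrogen on an aromatic ring.

Among the measured compounds shown here, no measured step removes this group outright. For the measured compounds named here, the single measured step, an 11-fold lower number from compound 2 to compound 3 (1.05 log units; beyond the scatter), only swaps the substituent carried on the benzyl ring, yet it is large, which marks this arm as weighty for the number in this assay. Compound 1, which also carries only hydrogen on that nitrogen though with other ring substituents, reaches no number at all. Taken together, a weakening step is expected for a 10-fold higher number from compound 3 to compound 4 (1.01 log units; beyond the scatter). Compound 4 is therefore estimated at 40000 nM, with a range from 8000 nM to 150000 nM, and a fair chance that this assay again returns only a limit.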

Compound 4, half-maximal inhibitory concentration: 1100 nM
The estimate for compound 4 lay 36-fold (1.56 log units) above the measured number; the whole stated range lies above it.
By their numbers in this assay, from the lowest: compound 4; then compound 3; then compound 2. At a limit, above all of these: compound 1.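

The 4-(methoxycarbonyl)benzyl arm is not needed for a low number in this assay, since hydrogen on this nitrogen does better: a 3.5-fold lower number from compound 3 to compound 4 (0.55 log units; beyond the scatter). The value of compound 1 is a limit, not a number: the limit of > 100000 nM in this assay, at which 1 of the 4 values shown sits. With hydrogen on that nitrogen in both compounds, the change of ring substituent, nitro in place of fluoro on an aromatic carbon, gives an at least 90-fold lower number from compound 1 to compound 4 (1.95 log units; beyond the scatter), so the poor showing of compound 1 does not count against hydrogen at this nitrogen.

As far as these compounds go, it remains open whether a small group such as methyl on this nitrogen, or an unsubstituted benzyl, would fall nearer compound 4 or compound 3. Also open, from the compounds shown here alone, is whether a longer chain to the core would keep the number of compound 4.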